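The source may report more compounds than this note shows. Statements on the series, on what has been measured and on what is new or still open speak of the compounds shown alone.

Among the measured compounds shown here, in an assay on CHO cells for displacement of a labelled ligand from 5-hydroxytryptamine receptor 1B (Homo sapiens) (a higher number here means a weaker inhibitor, a lower number a stronger inhibitor), compound 2 `c1ccc(N2CCN(CCCc3c[nH]c4ccc(-n5cnnc5)cc34)CC2)cc1` gives 13 nM, the lowest number so far, with compound 1 `c1ccc(CN2CCN(CCCc3c[nH]c4ccc(-n5cnnc5)cc34)CC2)nc1` at 18 nM within the scatter of it. For the measured compounds named here, the one measured step, a 1.4-fold lower number from compound 1 to compound 2 (0.14 log units; within the scatter), is the only comparison that touches the same ring nitrogen. Compound 3 `c1ccc(CCCN2CCN(CCCc3c[nH]c4ccc(-n5cnnc5)cc34)CC2)cc1` carries 3-phenylpropyl in place of phenyl on an amine nitrogen in a ring. As in compound 1, a chain now stands between the ring nitrogen and the aromatic ring; since that step stayed within the scatter, no step beyond the scatter is expected in this assay, a 1.2-fold higher number from compound 2 to compound 3 (0.06 log units; within the scatter). Compound 3 is expected to give 15 nM, between 5 nM and 45 nM.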

Compound 3, half-maximal inhibitory concentration: 85 nM
Estimate against measurement, compound 3: 5.7-fold (0.75 log units) below; measured number outside the range, above it.
By their numbers in this assay, from the lowest: compounds 2 and 1 (each within the scatter of the next); then compound 3.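

In this assay, the group on this amine nitrogen in a ring does matter: 3-phenylpropyl in place of phenyl gives a 6.5-fold higher number from compound 2 to compound 3 (0.82 log units; beyond the scatter), and phenethyl in place of pyridin-2-yl gives a 4.7-fold higher number from compound 1 to compound 3 (0.67 log units; beyond the scatter). Among the compounds shown here, the earlier pair, with its one step within the scatter, showed no such sensitivity at this position. No measurement here accounts for these steps.

Still open, going by these compounds, is how the number runs with benzyl or a longer chain on this nitrogen. Also open, on these data alone, is whether a pyridin-2-yl ring at the end of the propyl chain would give the same result as the phenyl ring of compound 3.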